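Changing the Aryl Group on a Ring Amine Nitrogen

This account rests on a few compounds, and the source may have more. Where it says the series, first, only, none or still open, it means among the compounds named here.

Three compounds have been measured in a functional assay on CHO cells with adenosine receptor A1 (Homo sapiens) as the target, read by cAMP accumulation and immunoassay, with a stated time of 6 min, tested at 0.01 uM; a lower number here means a stronger effect, a higher number a weaker effect of the compound at the concentration tested:
compound 1 `Nc1scc(CN2CCN(c3ccc([N+](=O)[O-])cc3)CC2)c1C(=O)c1ccc(Cl)cc1` gives -12%;
compound 2 `Nc1scc(CN2CCN(c3ccc(C(F)(F)F)cc3)CC2)c1C(=O)c1cccc(C(F)(F)F)c1` gives -12%;
compound 3 `Nc1scc(CN2CCN(c3c(F)cccc3F)CC2)c1C(=O)c1cccc(C(F)(F)F)c1` gives 2.1%.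

Compound 1 stands level with compound 2 at the digits shown, and together they are the lowest of the three numbers; compound 3 lies higher, the one measured step at this position being a number 14.1 percentage points higher from compound 2 to compound 3 (beyond the scatter).

Compound 4 `Nc1scc(CN2CCN(c3cccc(F)c3)CC2)c1C(=O)c1ccc(Cl)cc1` differs from compound 1 by 3-fluorophenyl in place of 4-nitrophenyl on an amine nitrogen in a ring. Among the compounds with values here, only that step from compound 2 to compound 3 bears on this change, and it involved different groups, so the guidance is loose. A modest rise in this assay is expected, roughly a number 8 percentage points higher from compound 1 to compound 4 (within the scatter). For compound 4 the estimate is -4%, with a range from -20% to 12%.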

Compound 4, a percentage reported as activity, at one concentration (the size of the read-out at that concentration, not a potency): -18%
Compound 4: the middle estimate sits 14 percentage points above what was measured, and the stated range covers the measured number.
By their numbers in this assay, from the lowest: compounds 4, 1 and 2 (each within the scatter of the next); then compound 3.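

In this assay, 3-fluorophenyl in place of 4-nitrophenyl gives a number 6 percentage points lower from compound 1 to compound 4 (within the scatter), so removing the nitro group at this position brings no change that can be told from the scatter. The rise in a number 14.1 percentage points higher from compound 2 to compound 3 (beyond the scatter) therefore does not extend to every fluorophenyl here, although that step was taken with a different group elsewhere on the core. Nothing available explains this result. From the compounds shown here alone, it remains open whether a pyridine ring or a methoxyphenyl on this nitrogen would also stay level, and whether 3-fluorophenyl would do so with the aryl ketone of compounds 2 and 3.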